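Amine variation at the benzylic position of the urea series

The compounds below may be only part of what the source reports. "The series", "measured", "known", "first", "only" and "open" are said of these compounds alone.

Within the data shown here, compound 2 `CCN(CC)Cc1ccc(NC(=O)Nc2ccc3ncnc(Nc4cccc(C(F)(F)F)c4)c3c2)cc1` is the weaker of the two measured members in a functional assay on A-431 cells (Homo sapiens) for antiproliferative activity, read by MTT assay, with a stated time of 72 h; a lower number here means a stronger inhibitor, a higher number a weaker inhibitor: compound 2 gives 3980 nM, while compound 1 `O=C(Nc1ccc(CN2CCCCC2)cc1)Nc1ccc2ncnc(Nc3cccc(C(F)(F)F)c3)c2c1` gives 1550 nM. Among the measured compounds shown here, the only measured step, a 2.6-fold higher number from compound 1 to compound 2 (0.41 log units; beyond the scatter), is the exchange of piperidin-1-yl for diethylamino on a saturated chain carbon bound to an aromatic carbon, and it moved the number beyond the scatter in the direction of a weaker inhibitor.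

Compound 3 `CN(C)Cc1ccc(NC(=O)Nc2ccc3ncnc(Nc4cccc(C(F)(F)F)c4)c3c2)cc1` continues in the same place: dimethylamino in place of diethylamino on a saturated chain carbon bound to an aromatic carbon. The measured step bears on this only loosely, since it compared a ring amine with an open-chain one, whereas here one open-chain amine is replaced by a smaller open-chain amine of the same kind. For the measured compounds named here, no measured pair shows what shortening the alkyl arms does. The expectation is therefore a step of a 1.3-fold lower number from compound 2 to compound 3 (0.12 log units; within the scatter), that is, no change beyond the scatter, with a wide range in both directions. Compound 3 is estimated at 3000 nM in this assay, between 1000 nM and 9000 nM.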

Compound 3, half-maximal inhibitory concentration: 1030 nM
For compound 3 the middle estimate is 2.9-fold (0.46 log units) above the measured one; the range from low to high includes it.
By their numbers in this assay, from the lowest: compounds 3 and 1 (each within the scatter of the next); then compound 2.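

In this assay, the exchange at this saturated chain carbon bound to an aromatic carbon gives a 3.9-fold lower number from compound 2 to compound 3 (0.59 log units; beyond the scatter), so the two open-chain amines, diethylamino and dimethylamino, are separated beyond the scatter and open-chain amines cannot be treated as one class here. The ring amine and the smaller open-chain amine are not separated, with a 1.5-fold lower number from compound 1 to compound 3 (0.18 log units; within the scatter), which means the earlier step from piperidin-1-yl to diethylamino does not read as a general difference between ring and open-chain amines; compound 3 goes against such a reading, and compound 2 alone stands apart, with steps beyond the scatter to both compound 1 and compound 3. The data at hand contain nothing that accounts for the separate position of diethylamino.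

Left open is whether other ring amines, such as pyrrolidine or morpholine, fall with piperidin-1-yl and dimethylamino or with diethylamino. Also open, as far as these compounds go, is how an unsubstituted amino group or dipropylamino reads at the same place, which would show whether diethylamino is an isolated case or part of a trend with the length of the alkyl arms.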